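The source may report more compounds than this note shows. Statements on the series, on what has been measured and on what is new or still open speak of the compounds shown alone.

In a functional assay on CHO cells for agonist activity at metabotropic glutamate receptor 5 (Homo sapiens), read by inositol phosphate accumulation (a higher number here means a weaker inhibitor, a lower number a stronger inhibitor), compound 1 `COc1cccc(C#Cc2csc(C)n2)c1` gives 49 nM, while compound 2 `COc1ncccc1C#Cc1csc(C)n1` gives 228 nM, the higher of the two numbers and set apart from compound 1 beyond the scatter. Compound 3 `Cc1nc(C#Cc2cccnc2Cl)cs1` differs from compound 2 by chloro in place of methoxy on an aromatic carbon. Within the data shown here, no measured pair shows this change, so the step from compound 2 to compound 3 in this assay is expected to be small, if anything toward a lower number, as a 1.9-fold lower number from compound 2 to compound 3 (0.28 log units; within the scatter). Compound 3 is therefore estimated at 120 nM in this assay, within a range from 35 nM to 400 nM.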

Compound 3, half-maximal inhibitory concentration: 45.5 nM
Compound 3: the middle estimate sits 2.6-fold (0.42 log units) above what was measured; measured number inside the range.
By their numbers in this assay, from the lowest: compounds 3 and 1 (each within the scatter of the next); then compound 2.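

In this assay, chloro in place of methoxy on the aromatic carbon next to the ring nitrogen gives a 5.0-fold lower number from compound 2 to compound 3 (0.70 log units; beyond the scatter). This pair shows that the number at this position responds to the group it carries, and that methoxy, with its oxygen, is not required for the lower number. No available evidence accounts for the step. From the compounds shown here alone, whether fluoro, methyl or an amine at this position would behave like chloro remains open, as does whether the same change would have a similar effect on the core of compound 1.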